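Fluoro for Trifluoromethyl on a Nucleoside Base

The compounds below may be only part of what the source reports. "The series", "measured", "known", "first", "only" and "open" are said of these compounds alone.

Two measured compounds frame this comparison. Compound 1 `Nc1ccn([C@H]2C[C@H](N)[C@@H](CO)O2)c(=O)n1` gives 4 uM in a functional assay on Sarcoma-180 cells (Mus musculus) for inhibition; on this read-out lower numbers stand for an effect already at smaller amounts and higher numbers for an effect only at larger amounts of compound. Among the measured compounds shown here, compound 2 `N[C@@H]1C[C@H](n2cc(C(F)(F)F)c(=O)[nH]c2=O)O[C@@H]1CO` gives 100 uM in this assay, the highest of the two numbers; its only neighbour, compound 1, lies at a lower number by a gap well beyond the scatter. The two compounds differ in more than one place, so only their two values can be set side by side.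

Compound 3 `N[C@@H]1C[C@H](n2cc(F)c(=O)[nH]c2=O)O[C@@H]1CO` has not yet been measured. It differs from compound 2 in a single spot: fluoro in place of trifluoromethyl on an aromatic carbon.

No measured step of this kind exists among these compounds, so the expectation rests on compound 2 alone. Compound 3 is expected to give about 40 uM, somewhere between 5 uM and 300 uM. That expectation means a step of a 2.5-fold lower number from compound 2 to compound 3 (0.40 log units; beyond the scatter), a modest move toward a lower number, with the possibility that it stays within the scatter.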

Compound 3, concentration for half-maximal effect: 1 uM
Beside the measured number, compound 3's estimate is 40-fold (1.60 log units) above it; the measured number lies below the stated range.
By their numbers in this assay, from the lowest: compound 3; then compound 1; then compound 2.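

On this aromatic carbon, ortho to a group of 1 heavy atom and two atoms from the ring nitrogen, the exchange of trifluoromethyl for fluoro is anything but a minor edit: in this assay it gives a 100-fold lower number from compound 2 to compound 3 (2.00 log units; beyond the scatter). The earlier pair, differing in more than one place, could not isolate any single spot, whereas this step shows that the group at this position alone can move the read-out strongly. Nothing shown accounts for the size of this step.

Going by these compounds, whether the step reflects the arrival of fluoro or only the departure of trifluoromethyl stays open, and a hydrogen, a chlorine or a methyl group on the same carbon would help to separate the two. On these data alone, it is also open whether the same exchange would have a comparable effect on the core of compound 1.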